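The source may hold more compounds than are shown below. What is called first, only, known or untested is meant among the compounds shown, and "the series" means these compounds.

Compound 1 `COc1cc(-c2nnc(SCC(=O)Nc3ccc(/C(C)=N/O)cc3)n2-c2ccccc2)cc(OC)c1OC`: 62%
Compound 2 `C/C(=N\O)c1ccc(NC(=O)CSc2nnc(-c3ccccc3)n2-c2ccccc2)cc1`: 52%

Of the compounds shown here, two have been measured in a functional assay on the whole organism (strain albino) for inhibition, with Rattus norvegicus as the target, read by paw edema, with stated times of 30 min and 2 h, at a dose of 0.28 mmol/kg by the oral route; on this read-out lower numbers stand for less inhibition and higher numbers for more inhibition at the one dose given (going by the name of the read-out). Compound 1 gives 62%, and compound 2 gives 52%. Compound 1 has the higher of the two numbers, but the step of a number 10 percentage points lower from compound 1 to compound 2 (within the scatter) lies within the scatter, so the two are not told apart.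

Compound 3 `C=CCn1c(SCC(=O)Nc2ccc(/C(C)=N/O)cc2)nnc1-c1cc(OC)c(OC)c(OC)c1` has not yet been measured. It differs from compound 1 by allyl in place of phenyl on an aromatic nitrogen. Within the data shown here, the only measured step, from compound 1 to compound 2, changes a group at a different place on the shared core and was within the scatter; it does not touch the ring nitrogen where compound 3 differs. Among the measured compounds shown here, no measured step therefore speaks directly to this change, and a small step or none beyond the scatter is the plainest expectation in this assay. For compound 3 the number is estimated as 55%, between 40% and 70%, an expected step of a number 7 percentage points lower from compound 1 to compound 3 (within the scatter).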

Compound 3, a percentage reported as inhibition, in the whole organism at one dose (the size of the read-out at that dose, not a potency): 53%
Compound 3: middle estimate off by 2 percentage points, on the high side; the measured number falls inside the stated range.
By their numbers in this assay, from the lowest: compounds 2, 3 and 1 (each within the scatter of the next).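

In this assay, the ring nitrogen now has its first measured change: allyl in place of phenyl gives a number 9 percentage points lower from compound 1 to compound 3 (within the scatter). On this one pair, replacing a six-membered aromatic ring of 6 heavy atoms with an open group of 3 heavy atoms leaves the two compounds not told apart, so an aromatic ring at this position is not needed for a number of this size at the one dose given. Nothing available gives a reason for this result.

Only these two groups, both made of carbon alone, are shown on this nitrogen, so it remains open whether an aminoethyl chain, a carboxylic acid or a longer alkyl chain there would move the number beyond the scatter. As far as these compounds go, it is also open whether allyl would give a similar number with phenyl in place of the 3,4,5-trimethoxyphenyl group.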